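Trifluoromethyl on the phenyl group of compound 3

A few compounds are considered here, and "the series" means these few. Any claim that something is new, unique, unknown or untested is made for them only; others in the source may bear on it.

Of the compounds shown here, three of the shared core have been measured in an assay on HL-60 cells for inhibition of glutathione S-transferase P (Homo sapiens); a higher number here means a weaker inhibitor, a lower number a stronger inhibitor. Compound 1 `C=C(C)C(=O)c1ccc(OCc2nc(C)no2)cc1C` gives 5000 nM, compound 2 `C=C(C)C(=O)c1ccc(OCc2nc(-c3ccccc3)no2)c(C)c1C` gives 1800 nM, and compound 3 `C=C(CC)C(=O)c1ccc(OCc2nc(-c3ccccc3)no2)c(Cl)c1Cl` gives 3600 nM. Among these three numbers compound 3 stands second highest in this assay; the nearest number is that of compound 1, which is higher but within the scatter, and the furthest is that of compound 2, which is lower and also within the scatter. Within the data shown here, no pair among the three differs in a single place, so no step between measured compounds can be read off, and the three numbers do not separate from one another.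

Compound 4 `C=C(CC)C(=O)c1ccc(OCc2nc(-c3ccc(C(F)(F)F)cc3)no2)c(Cl)c1Cl` has not yet been measured in this assay. It differs from compound 3 in one place: trifluoromethyl in place of hydrogen on an aromatic carbon. Nothing in the measured set shows what a group on the phenyl does, so the step in this assay is expected to be small, with no firm direction and probably not beyond the scatter. The expected step is a 1.3-fold lower number from compound 3 to compound 4 (0.11 log units; within the scatter). For compound 4 in this assay the estimated value is 2800 nM, with an expected range from 900 nM to 8000 nM.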

Compound 4, half-maximal inhibitory concentration: > 40000 nM
Compound 4: only a limit was reported; the forecaster's own chance of this, stated with the estimate: 10%; middle value at least 14-fold (1.15 log units) away from the limit.
By their numbers in this assay, from the lowest: compounds 2, 3 and 1 (each within the scatter of the next, the first and the last beyond it). At a limit, above all of these: compound 4.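

In this assay, among these compounds, the change from phenyl to 4-(trifluoromethyl)phenyl gives an at least 11-fold higher number from compound 3 to compound 4 (1.04 log units; beyond the scatter), so this place on the aromatic ring is not neutral for the series, and this is the first step that can be read from a change in one place. Compound 4 gives > 40000 nM, which is a limit of the assay and not a number. The step therefore fixes a direction and a minimum size for this single replacement, with hydrogen on this aromatic carbon giving a measurable value and trifluoromethyl reaching the limit, and only one compound of the series stands there: the limit of > 40000 nM in this assay, at which 1 of the 4 values shown sits.

The compounds shown leave open whether the loss belongs to trifluoromethyl in particular or to any group at this carbon; fluorine, a methoxy group, an amine or a carboxylic acid at the same place would separate those readings. From the compounds shown here alone, it also remains open whether the same replacement on the phenyl group of compound 2 would give a step of similar size, or whether the step depends on the rest of the shared core.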